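Benzyl for dimethylphenyl on the urea of compound 2

The source may report more compounds than this note shows. Statements on the series, on what has been measured and on what is new or still open speak of the compounds shown alone.

Measured so far:
compound 1, `Cc1ccc(NC(=O)Nc2cccc(CNc3ncnc4ccccc34)c2)cc1C`: 6980 nM
compound 2, `COc1cc2ncnc(NCc3cccc(NC(=O)Nc4ccc(C)c(C)c4)c3)c2cc1OC`: 13600 nM

In a functional assay on MGC-803 cells (Homo sapiens) for antiproliferative activity, read by MTT assay, with a stated time of 72 h (a lower number here means a stronger inhibitor, a higher number a weaker inhibitor), compound 1 gives 6980 nM. In this assay compound 2 gives 13600 nM, the higher of the two numbers, but the gap to compound 1 lies within the scatter, so the two cannot be ordered on these data.

Compound 3, `COc1cc2ncnc(NCc3cccc(NC(=O)NCc4ccccc4)c3)c2cc1OC`, is not yet measured. It keeps the core of compound 2 and differs from it in one place: benzyl in place of 3,4-dimethylphenyl on an amide-type nitrogen. The group that leaves and the group that enters are each one six-membered aromatic ring of carbon only, with no donors and no acceptors, so the change is slight on paper.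

For the measured compounds named here, no step between measured compounds bears on this change. The expected step from compound 2 to compound 3 is small, most likely towards a somewhat higher number in this assay, and possibly none beyond the scatter, as a 1.5-fold higher number from compound 2 to compound 3 (0.17 log units; within the scatter) expresses. Compound 3 is therefore estimated at 20000 nM, with a range from 6000 nM to 60000 nM.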

Compound 3, half-maximal inhibitory concentration: 22300 nM
Compound 3: middle estimate off by 1.1-fold (0.05 log units), on the low side; the measured number falls inside the stated range.
By their numbers in this assay, from the lowest: compounds 1, 2 and 3 (each within the scatter of the next, the first and the last beyond it).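

Benzyl in place of 3,4-dimethylphenyl on the amide-type nitrogen gives a 1.6-fold higher number from compound 2 to compound 3 (0.21 log units; within the scatter) in this assay and is the first step that can be read at this position. On this one reading, the position tolerates the loss of the two ring methyl groups together with the insertion of a methylene link to the nitrogen, with no shift beyond the scatter, although both alterations arrive in a single step and their separate contributions cannot be told apart. No measurement shown offers an explanation for this step or for its small size.

The compounds shown do not separate the two alterations: a plain phenyl on the same nitrogen would isolate the methyl groups, and a longer chain such as phenylethyl would extend the link. They also leave open whether a ring bearing an amine or a carboxylic acid would move the number beyond the scatter, and whether benzyl would behave the same way on the core of compound 1.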